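From compound 3 to compound 4: a half-life estimate

The compounds below may be only part of what the source reports. "The series", "measured", "known", "first", "only" and "open" are said of these compounds alone.

Measured in an in vitro ADME assay on microsomes from liver (Homo sapiens) for metabolic stability, tested at 1 uM (on this read-out lower numbers stand for a shorter-lived compound and higher numbers for a longer-lived compound), the three compounds read:
- Compound 1 `CC(C)[C@]1(C(=O)N2C[C@@H]3C[C@H]2CN3C(=O)CC(C)(C)C)CC[C@@H](NC2CCOCC2)C1` gives > 2 h as a limit
- Compound 2 `CC(C)[C@]1(C(=O)N2C[C@@H]3C[C@H]2CN3C(=O)C(C)(C)C)CC[C@@H](NC2CCOCC2)C1` gives > 2 h as a limit
- Compound 3 `CC(OC(=O)N1C[C@@H]2C[C@H]1CN2C(=O)[C@@]1(C(C)C)CC[C@@H](NC2CCOCC2)C1)C(F)(F)F` gives 1.3 h as a measured number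

Compound 3 is the only one of the three with an actual number; the other two stop at a limit. Compound 4 `CC(C)[C@]1(C(=O)N2C[C@@H]3C[C@H]2CN3C(=O)CCC(F)(F)F)CC[C@@H](NC2CCOCC2)C1` differs from it by 3,3,3-trifluoropropyl in place of 1-(trifluoromethyl)ethoxy on a carbonyl carbon with 3,3,3-trifluoropropyl in place of 1-(trifluoromethyl)ethoxy on a carbonyl carbon. Going by the values given here, two measured steps bear on this. Putting 1-(trifluoromethyl)ethoxy in place of neopentyl gave an at least 1.5-fold lower number from compound 1 to compound 3 (0.18 log units; that floor lies within the scatter) and putting it in place of tert-butyl gave an at least 1.5-fold lower number from compound 2 to compound 3 (0.18 log units; that floor lies within the scatter) so both are floors rather than sizes. The exchange of neopentyl for tert-butyl is a step that the two limits leave unreadable from compound 1 to compound 2 and adds nothing. Among the compounds with values here, compound 4 gives up the 1-(trifluoromethyl)ethoxy, so the reverse of an at least 1.5-fold lower number from compound 2 to compound 3 (0.18 log units; that floor lies within the scatter) suggests an upward direction, although no measured compound carries 3,3,3-trifluoropropyl. The expected step is a 1.5-fold higher number from compound 3 to compound 4 (0.19 log units; within the scatter) and it may not clear the usual scatter. Compound 4 is estimated at 2 h with an expected range of 1.1 h to 3.5 h and this assay may well report only a limit for it.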

Compound 4, half-life: > 2 h
Compound 4 ended at the assay's limit; the forecaster's own chance of this, stated with the estimate: 45%; the middle value sits exactly at the limit.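

In this assay, exchanging 1-(trifluoromethyl)ethoxy for 3,3,3-trifluoropropyl on a carbonyl carbon gives an at least 1.5-fold higher number from compound 3 to compound 4 (0.18 log units; that floor lies within the scatter), so this step can be stated only as a floor and does not establish a real separation between the two compounds. Going by these compounds alone, compound 4 keeps the three fluorine atoms but not the oxygen, and it shows that a fluorinated chain at this place can end at the limit, as the neopentyl of compound 1 and the tert-butyl of compound 2 do, while the only measured number still belongs to the 1-(trifluoromethyl)ethoxy of compound 3. The steps that link compound 4 to compound 1 and compound 2 cannot be read, because all three compounds stop at the same value, which is a limit and not a number: the limit of > 2 h in this assay, at which 3 of the 4 values shown sit.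

On these data alone, how far compound 1, compound 2 and compound 4 lie past that limit stays open, so no order among them can be given. Also open, as far as these compounds go, is whether the oxygen or the fluorine atoms matter more here, which a plain isopropoxy on the same carbonyl carbon would begin to separate.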